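From 4-bromophenyl to 4-methoxyphenyl: notes on compound 3

This account rests on a few compounds, and the source may have more. Where it says the series, first, only, none or still open, it means among the compounds named here.

In a functional assay on DU-145 cells (Homo sapiens) for cytotoxicity, read by trypan blue exclusion, with a stated time of 96 h (a lower number here means a stronger inhibitor, a higher number a weaker inhibitor), compound 1 (`COC(=O)CNc1cc(CS(=O)(=O)/C=C/c2c(OC)cc(OC)cc2OC)ccc1OC`) gives 100 nM as its reading and compound 2 (`COC(=O)C(Nc1cc(CS(=O)(=O)/C=C/c2c(OC)cc(OC)cc2OC)ccc1OC)c1ccc(Br)cc1`) gives 300 nM on the same scale. Compound 2 therefore holds the higher of the two numbers and is the weaker inhibitor of the pair. Among the compounds with values here, the only measured step is a 3.0-fold higher number from compound 1 to compound 2 (0.48 log units; beyond the scatter) on placing 4-bromophenyl in place of hydrogen on the saturated chain carbon, a modest step beyond the scatter.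

Compound 3 (`COC(=O)C(Nc1cc(CS(=O)(=O)/C=C/c2c(OC)cc(OC)cc2OC)ccc1OC)c1ccc(OC)cc1`) differs from compound 2 by methoxy in place of bromo on an aromatic carbon, para to a large group (methoxy in place of bromo on an aromatic carbon). Within the data shown here, no measured step tests a change at this aromatic carbon. Compound 2 offers only indirect guidance, with a 3.0-fold higher number from compound 1 to compound 2 (0.48 log units; beyond the scatter) as the modest effect of adding the whole 4-bromophenyl group, so a swap within that group is expected to be smaller. The expected change is a 1.2-fold lower number from compound 2 to compound 3 (0.08 log units; within the scatter) in this assay and stays within the scatter, with no firm direction. Compound 3 is estimated at 250 nM with an expected range of 90 nM to 700 nM for a single measurement.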

Compound 3, half-maximal inhibitory concentration: 250 nM
Beside the measured number, compound 3's estimate shows no gap at the digits printed, and the stated range covers the measured number.
By their numbers in this assay, from the lowest: compound 1; then compounds 3 and 2 (each within the scatter of the next).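

In this assay, within the data shown here, the exchange of bromo for methoxy on an aromatic carbon, para to a large group, gives a 1.2-fold lower number from compound 2 to compound 3 (0.08 log units; within the scatter) and so opens a place that no earlier step touched, with no difference there that can be separated from the scatter. On the saturated chain carbon, 4-methoxyphenyl in place of hydrogen gives a 2.5-fold higher number from compound 1 to compound 3 (0.40 log units; beyond the scatter) and stands with the earlier 3.0-fold higher number from compound 1 to compound 2 (0.48 log units; beyond the scatter) as a second step beyond the scatter in the same direction, which shows that the rise in the number is not confined to the bromo compound within this set of three. No supporting data bear on why compound 2 and compound 3 read so closely, or on why either reads above compound 1.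

Both substituents tried at the aromatic carbon leave open how far this tolerance extends, and an amine or a carboxylic acid at that place would test it with a quite different group. The compounds shown also cannot separate the contribution of the aromatic ring from that of its substituent on the chain carbon, a question that an unsubstituted phenyl or a simple methyl there would address.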